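The compounds below may be only part of what the source reports. "The series", "measured", "known", "first", "only" and "open" are said of these compounds alone.

Working notes on the series. In an ADME assay on KB cells (Homo sapiens) for cytotoxicity, read by resazurin assay, with a stated time of 72 h (a lower number here means a stronger inhibitor, a higher number a weaker inhibitor), compound 1 (`COc1cccc(C(=O)/C=C/c2cccnc2)c1`) gives 2300 nM and compound 2 (`COc1ccc(C(=O)/C=C/c2cccnc2)cc1`) gives 21700 nM as the higher of the two numbers, a gap that lies beyond the scatter. Each of these two structures carries one methoxy group on the shared core, placed differently. Within the data shown here, no measured pair yet shows what adding a methoxy group does to the number.

Compound 3 (`COc1ccc(C(=O)/C=C/c2cccnc2)cc1OC`) is reached from compound 2 by one change (methoxy in place of hydrogen on an aromatic carbon), namely methoxy in place of hydrogen on an aromatic carbon, ortho to a methoxy group and meta to a large group. The methoxy group of compound 1 at 2300 nM also stands meta to a large group, so compound 3 may move part of the way towards that number. A moderate step to a lower number is therefore expected in this assay for this change, although a step within the scatter remains possible. The expected step (a 2.2-fold lower number from compound 2 to compound 3 (0.34 log units; beyond the scatter)) is only a rough guide, resting on two measured compounds. For compound 3 the estimated value is 10000 nM with an expected range from 3000 nM to 30000 nM as the likely span.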

Compound 3, half-maximal inhibitory concentration: 22800 nM
Compound 3: middle estimate off by 2.3-fold (0.36 log units), on the low side; the measured number falls inside the stated range.
By their numbers in this assay, from the lowest: compound 1; then compounds 2 and 3 (each within the scatter of the next).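

In this assay, methoxy in place of hydrogen on an aromatic carbon, ortho to a methoxy group and meta to a large group, gives a 1.1-fold higher number from compound 2 to compound 3 (0.02 log units; within the scatter), so on compound 2 this position shows no response to the change. The same kind of change, read from the other side, gives a 9.9-fold higher number from compound 1 to compound 3 (1.00 log units; beyond the scatter), so a methoxy group meta to a large group does not by itself go with the low number of compound 1, and a second methoxy group reads differently depending on which compound receives it. No measurement at hand accounts for the difference between these two steps.

Going by these compounds, what a single methoxy group does to the shared core remains open, as does whether the two methoxy groups of compound 3 act separately or together. Also open, on these data alone, is whether a different group at this position, such as an amine, a hydroxyl or a longer alkoxy chain, would leave the number as flat as methoxy does on compound 2.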